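A few compounds are considered here, and "the series" means these few. Any claim that something is new, unique, unknown or untested is made for them only; others in the source may bear on it.

Compound 1 `Fc1cccc(N2CCN(CCCOc3ccc4c(c3)CCC4)CC2)c1` gives 42% in a functional assay on the whole organism for inhibition, with Mus musculus as the target, at a dose of 25 mg/kg by the oral route; on this read-out higher numbers stand for more inhibition at the one dose given (going by the name of the read-out) and lower numbers for less inhibition.
Compound 2 `Fc1ccc(N2CCN(CCCCCOc3ccc4c(c3)CCC4)CC2)cc1` gives 71% in this assay.

Of these two, compound 1 stands lowest in this assay, and the number for compound 2 lies above it by more than the usual scatter. Compound 3 `COc1ccccc1N1CCN(CCCOc2ccc3c(c2)CCC3)CC1` differs from compound 1 by 2-methoxyphenyl in place of 3-fluorophenyl on an amine nitrogen in a ring. Among the compounds with values here, no measured pair shows this change, so the data give no step to lean on; a shift no larger than the scatter, in either direction, is expected in this assay. Compound 3 is therefore expected to give about 50%, between 20% and 80%, a step of a number 8 percentage points higher from compound 1 to compound 3 (within the scatter).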

Compound 3, a percentage reported as inhibition, in the whole organism at one dose (the size of the read-out at that dose, not a potency): 19%
For compound 3 the middle estimate is 31 percentage points above the measured one; the measured number lies below the stated range.
By their numbers in this assay, from the lowest: compound 3; then compound 1; then compound 2.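

Within the data shown here, with the rest of compound 1 held fixed, the group on the amine nitrogen in the ring proves to matter in this assay: 2-methoxyphenyl in place of 3-fluorophenyl gives a number 23 percentage points lower from compound 1 to compound 3 (beyond the scatter) and is the first single change that can be read, since compound 1 and compound 2 differ in more than one place. Nothing at hand explains this loss of inhibition. From the compounds shown here alone, it remains open how a plain phenyl or a pyridyl group would fare on that nitrogen, and whether 2-methoxyphenyl would bring a similar step on the chain of compound 2.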